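From Nitro to Cyano: A Small Step Expected

The source may report more compounds than this note shows. Statements on the series, on what has been measured and on what is new or still open speak of the compounds shown alone.

Measured in a functional assay on MDA-MB-231 cells (Homo sapiens) for antiproliferative activity, read by CCK-8 assay, with a stated time of 72 h; on this read-out higher numbers stand for weaker inhibition and lower numbers for stronger inhibition:
- compound 1 `Cc1cc(Nc2cc(N3CCN(C)CC3)nc(Nc3ccc([N+](=O)[O-])cc3)n2)n[nH]1`: 84.4 nM
- compound 2 `Cc1cc(Nc2cc(N3CCN(C)CC3)nc(Nc3ccc(Cl)cc3)n2)n[nH]1`: 138 nM

Only these two numbers are available, and compound 1 lies within the usual scatter of compound 2, so they set no firm order. Compound 3 `Cc1cc(Nc2cc(N3CCN(C)CC3)nc(Nc3ccc(C#N)cc3)n2)n[nH]1` keeps the core of compound 1 and changes one group: cyano in place of nitro on an aromatic carbon. This is cyano in place of nitro on an aromatic carbon.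

Among the measured compounds shown here, one measured step bears on this, since it replaces the same nitro group with chloro: a 1.6-fold higher number from compound 1 to compound 2 (0.21 log units; within the scatter). That single step stayed within the scatter, so no change beyond the scatter is expected in this assay, and no clear direction. The estimated step is a 1.1-fold higher number from compound 1 to compound 3 (0.05 log units; within the scatter). For compound 3 the expected value is 95 nM, with an estimated range of 40 nM to 230 nM.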

Compound 3, half-maximal inhibitory concentration: 75.7 nM
Compound 3: middle estimate off by 1.3-fold (0.10 log units), on the high side; low and high end bracket the measured number.
By their numbers in this assay, from the lowest: compounds 3, 1 and 2 (each within the scatter of the next).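

In this assay the change from nitro to cyano gives a 1.1-fold lower number from compound 1 to compound 3 (0.05 log units; within the scatter) and the change from chloro to cyano gives a 1.8-fold lower number from compound 2 to compound 3 (0.26 log units; within the scatter), and both steps lie within the scatter. Nitro, chloro and cyano have now all been carried at this place on the six-membered aromatic ring, and the numbers do not separate any of them. The nitro group is therefore not required at this place for activity in this range, since compound 3 lacks it and stays within the scatter of compound 1.

Going by these compounds, whether a group of another kind at this place, such as an amine or a carboxylic acid, would stay in the same range remains open. Nothing measured here explains why these three groups give such similar numbers.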